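Half-life notes on the amide series

The source may report more compounds than this note shows. Statements on the series, on what has been measured and on what is new or still open speak of the compounds shown alone.

In an ADME assay on the whole organism (strain CD1) for metabolic stability, with Mus musculus as the target, read by LC-MS, at a dose of 5 mg/kg by the oral route (a lower number here means that the compound disappears faster, a higher number that the compound lasts longer), compound 2 (`Cc1c(Oc2cnc(C(=O)N[C@@H](CO)CC(F)(F)F)cn2)ccc2c1B(O)OC2`) stands at 3 h and compound 1 (`CCC[C@H](CO)NC(=O)c1cnc(Oc2ccc3c(c2C)B(O)OC3)cn1`) at 4.5 h with the two values within the scatter of each other. Compound 3 (`Cc1c(Oc2cnc(C(=O)N3CC(C)(O)C3)cn2)ccc2c1B(O)OC2`) has 3-hydroxy-3-methylazetidin-1-yl in place of (3,3,3-trifluoro-1-(hydroxymethyl)propyl)amino on a carbonyl carbon. Going by the values given here, the only measured step (a 1.5-fold lower number from compound 1 to compound 2 (0.18 log units; within the scatter)) puts trifluoromethyl in place of ethyl and stays within the scatter. Among the compounds with values here, no measured step covers replacement of the whole group, so no direction is supported. The estimated step (a 1.2-fold lower number from compound 2 to compound 3 (0.08 log units; within the scatter)) is expected to stay within the scatter, though with wide uncertainty. Compound 3 is expected at 2.5 h (0.9 h to 6 h).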

Compound 3, half-life: 6.8 h
Compound 3: the middle estimate sits 2.7-fold (0.43 log units) below what was measured; the whole stated range lies below it.
By their numbers in this assay, from the lowest: compounds 2, 1 and 3 (each within the scatter of the next, the first and the last beyond it).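

In this assay, going by these compounds alone, 3-hydroxy-3-methylazetidin-1-yl on the carbonyl carbon gives the first step beyond the scatter, though a modest one (a 2.3-fold higher number from compound 2 to compound 3 (0.36 log units; beyond the scatter)). The same group set against (1-(hydroxymethyl)butyl)amino stays within the scatter (a 1.5-fold higher number from compound 1 to compound 3 (0.18 log units; within the scatter)), so the clear change holds against only one of the two open chains. No supporting data bear on the reason for this result.

The compounds shown leave open whether the four-membered ring or its hydroxy and methyl groups carry the difference. As far as these compounds go, how a piperidine amide or an azetidine lacking the methyl would compare also remains open.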